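Fluoro to methyl on a pyrimidine amide series

A few compounds are considered here, and "the series" means these few. Any claim that something is new, unique, unknown or untested is made for them only; others in the source may bear on it.

Compound 2 `CNC(=O)c1cc(Oc2ccc(NC(=O)c3cc(-c4ccc(F)cc4)ncn3)cc2F)ccn1` was tested in a functional assay on MCF7 cells (Homo sapiens) for cytotoxicity, read by MTT assay, with a stated time of 72 h (on this read-out higher numbers stand for weaker inhibition and lower numbers for stronger inhibition), and gave only a limit, > 100000 nM, so its number is not known; it is one of the measured compounds that sit at the limit of > 100000 nM in this assay, at which 1 of the 3 values shown sits. Two related compounds share its core with a different pyrimidine arrangement and no fluoro on the central ring: compound 1 `CNC(=O)c1cc(Oc2ccc(NC(=O)c3nccc(-c4ccc(OC)cc4)n3)cc2)ccn1` gives 35200 nM in this assay, and compound 3 `CNC(=O)c1cc(Oc2ccc(NC(=O)c3nccc(-c4ccccc4)n3)cc2)ccn1` gives 39100 nM. Going by the values given here, the only measured step, a 1.1-fold higher number from compound 1 to compound 3 (0.05 log units; within the scatter), concerns a different group on the distal phenyl ring and reads within the scatter.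

Compound 4 `CNC(=O)c1cc(Oc2ccc(NC(=O)c3cc(-c4ccc(C)cc4)ncn3)cc2F)ccn1` differs from compound 2 by methyl in place of fluoro on an aromatic carbon. Among the compounds with values here, no measured step in this set covers a fluoro-to-methyl exchange, and the step from compound 1 to compound 3 only shows that a change on that phenyl ring can pass without a visible effect. The expected step of a number no higher from compound 2 to compound 4 (the limit leaves the size open) is therefore not expected to exceed the scatter in either direction, and compound 4 is estimated to lie around 100000 nM, between 40000 nM and 300000 nM, with a good chance that this assay again returns only a limit for compound 4.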

Compound 4, half-maximal inhibitory concentration: 19200 nM
Beside the measured number, compound 4's estimate is 5.2-fold (0.72 log units) above it; the whole stated range lies above it.
By their numbers in this assay, from the lowest: compounds 4, 1 and 3 (each within the scatter of the next, the first and the last beyond it). At a limit, above all of these: compound 2.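

Going by these compounds alone, the exchange of 4-fluorophenyl for 4-methylphenyl gives the first step in this set that clearly exceeds the scatter in this assay: an at least 5.2-fold lower number from compound 2 to compound 4 (0.71 log units; beyond the scatter). Within the data shown here, the only earlier step on the distal phenyl ring, a 1.1-fold higher number from compound 1 to compound 3 (0.05 log units; within the scatter), lay within the scatter, so it could not show that a group at this place can shift the read-out; this pair shows that it can, at least on the arrangement shared by compound 2 and compound 4, where a single heavy atom para to a large group is all that changes. Compound 2 stands at a limit, not at a number, so the true size of the step stays open at its upper end: the limit of > 100000 nM in this assay, at which 1 of the 4 values shown sits.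

The compounds shown leave open whether the gain belongs to methyl in particular or would also come with an ethyl group, a chlorine atom, a trifluoromethyl group or an amine in the same place. They also leave open why the exchange has this effect, and whether it would carry over to the pyrimidine arrangement of compound 3, which has no fluoro on the central ring.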